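The source may hold more compounds than are shown below. What is called first, only, known or untested is meant among the compounds shown, and "the series" means these compounds.

In an ADME assay on the whole organism (strain Sprague-Dawley) for pharmacokinetics, with Rattus norvegicus as the target, using cassette dosing, at a dose of 1 mg/kg by the oral route (a higher number here means that a larger share of the oral dose reaches the circulation, a lower number that a smaller share of the oral dose reaches the circulation), compound 3 (`O=c1[nH]c2ccc(-c3cc(C[C@]4(O)CC[C@@H](Cc5ccccc5)CC4)no3)cc2o1`) gives 8.4%. That lies within the scatter of compound 2 (`O=C(C[C@]1(O)CC[C@@H](Cc2ccc(F)c(F)c2)CC1)Nc1ccc2[nH]c(=O)oc2c1`) at 12.1%. Compound 1 (`O=C(C[C@]1(O)CC[C@@H](Cc2ccc(OC(F)(F)F)cc2)CC1)Nc1ccc2[nH]c(=O)oc2c1`) gives 53.4%. The gap between compound 3 and compound 1 lies well beyond the scatter. Compound 4 (`O[C@]1(Cc2cc(-c3cn[nH]c3)on2)CC[C@H](Cc2ccccc2)CC1`) differs from compound 3 in one place: a group of 5 heavy atoms (3 carbon, 2 nitrogen; one five-membered aromatic ring with 2 hetero atoms) in place of a group of 10 heavy atoms (7 carbon, 1 nitrogen, 2 oxygen; one five-membered aromatic ring with 2 hetero atoms, one six-membered aromatic ring of carbon only), on an aromatic carbon. The incoming 1H-pyrazol-4-yl sits on an aromatic carbon, next to the ring oxygen.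

Going by the values given here, no measured step covers this swap. Among the compounds with values here, the only one available, a number 41.3 percentage points lower from compound 1 to compound 2 (beyond the scatter), concerns a different group elsewhere in the molecule, so it shows only that a single change can shift this read-out by a large amount. A large step is therefore possible here, but its size is poorly constrained. With compound 3 at 8.4%, there is far more room for the number to rise than to fall, so an upward move is expected. The expected change is a number 16.6 percentage points higher from compound 3 to compound 4 (beyond the scatter), and this estimate is a loose one. Compound 4 is estimated at 25%, with an expected range from 8% to 50%.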

Compound 4, oral bioavailability: 46.3%
Estimate against measurement, compound 4: 21.3 percentage points below; low and high end bracket the measured number.
By their numbers in this assay, from the lowest: compounds 3 and 2 (each within the scatter of the next); then compounds 4 and 1 (each within the scatter of the next).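

Compounds 1 and 2 showed that the group on the saturated chain carbon can move the number strongly, and this result shows that the other end of the molecule can as well. In this assay, putting 1H-pyrazol-4-yl on the aromatic carbon next to the ring oxygen gives a number 37.9 percentage points higher from compound 3 to compound 4 (beyond the scatter), so this position is a second place where one change has a large effect, here with a group of 5 heavy atoms and one ring replacing a group of 10 heavy atoms and two rings. No measurement shown here accounts for this rise.

This single swap changes the atom count, the ring count and the hydrogen-bond acceptor count together, so their contributions cannot be separated. As far as these compounds go, how a plain phenyl ring or a primary amine would behave on this aromatic carbon remains open.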